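The source may report more compounds than this note shows. Statements on the series, on what has been measured and on what is new or still open speak of the compounds shown alone.

Measured so far:
compound 1 `COc1ccc(C(c2ccccc2O)c2cccc3ccccc23)c(OC)c1OC` — in a functional assay on MCF7 cells (Homo sapiens) for inhibition, read by sulforhodamine B assay, with a stated time of 48 h (a lower number here means a stronger inhibitor, a higher number a weaker inhibitor), compound 1 gives 16600 nM.
compound 2 `COc1ccc(/C(=N/OC(C)=O)c2cccc3ccccc23)c(OC)c1OC` — compound 2 reaches only a limit, > 20000 nM.
compound 3 `COc1cc(COC(c2ccc(OC)c(OC)c2OC)c2cccc3ccccc23)cc(OC)c1` — compound 3 likewise reaches only a limit, > 20000 nM.

Compound 3 therefore stands at the edge of what this assay reports: its value is a limit, not a number, and the same holds for (the limit of > 20000 nM in this assay, at which 2 of the 3 values shown sit). Only compound 1 gives a number, and that number is weak. For the measured compounds named here, no step between measured compounds that differ in one place is available, so nothing measured here sets the size of a single change.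

Compound 4 `COc1ccc(C(OCc2ccccc2)c2cccc3ccccc23)c(OC)c1OC` differs from compound 3 in one place: phenyl in place of 3,5-dimethoxyphenyl on a saturated chain carbon bound to an oxygen on a saturated carbon. With compound 3 at a limit, the step expected is none beyond the scatter, and compound 4 is expected most likely to sit at the same limit. The expected step is a step that the limit leaves unreadable from compound 3 to compound 4. For compound 4 the estimated value in this assay is 22000 nM, within the range 8000 nM to 60000 nM.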

Compound 4, half-maximal inhibitory concentration: 14100 nM
Estimate against measurement, compound 4: 1.6-fold (0.19 log units) above, within the range that was stated.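

In this assay compound 3 is only a limit, > 20000 nM. Phenyl in place of 3,5-dimethoxyphenyl on a saturated chain carbon bound to an oxygen on a saturated carbon gives the first number at this position among the compounds shown, and the step is an at least 1.4-fold lower number from compound 3 to compound 4 (0.15 log units; that floor lies within the scatter), so the change can be bounded on one side only. Benzyloxy in place of 2-hydroxyphenyl on a saturated chain carbon bound to two aromatic carbons gives a 1.2-fold lower number from compound 1 to compound 4 (0.07 log units; within the scatter), so this second change shows no readable effect and the number stays weak.

The full size of the step from the 3,5-dimethoxybenzyl to the benzyl group cannot be read, and the series still touches the edge of the reported range: the limit of > 20000 nM in this assay, at which 2 of the 4 values shown sit. From the compounds shown here alone, whether an amine or a carboxylic acid in place of the phenyl, or a longer chain there, moves the number beyond the scatter remains open.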